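Restoring the amide hydrogen at the pyridine carboxamide

The compounds below may be only part of what the source reports. "The series", "measured", "known", "first", "only" and "open" are said of these compounds alone.

Of the compounds shown here, two have been measured in an assay for inhibition of 6-phosphofructo-2-kinase/fructose-2,6-bisphosphatase 3 (Homo sapiens), read by ADP-Glo, with a stated time of 2 h; on this read-out lower numbers stand for stronger inhibition and higher numbers for weaker inhibition. Compound 1 `CNC(=O)c1ccncc1Nc1cc(-c2ccc3ccn(C)c3c2)c2nccnc2c1` gives 83 nM, and compound 2 `CN(C)C(=O)c1ccncc1Nc1cc(-c2ccc3ccn(C)c3c2)c2nccnc2c1` gives 499 nM. Within the data shown here, the single step between them, a 6.0-fold higher number from compound 1 to compound 2 (0.78 log units; beyond the scatter), shows that methyl in place of hydrogen on the amide-type nitrogen weakened inhibition, leaving compound 2 with the highest number of the two.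

Compound 3 `CC(=O)N1CCC(NC(=O)c2ccncc2Nc2cc(-c3ccc4ccn(C)c4c3)c3nccnc3c2)C1` differs from compound 2 by (1-acetylpyrrolidin-3-yl)amino in place of dimethylamino on a carbonyl carbon. The change brings back one hydrogen-bond donor on the amide-type nitrogen, the feature whose loss is measured in the step from compound 1 to compound 2, so a lower number than compound 2 is expected in this assay, though the entering group is much larger than methyl and nothing measured here speaks to that size. Compound 3 is therefore estimated at 120 nM, within a range of 40 nM to 400 nM, an expected step of a 4.2-fold lower number from compound 2 to compound 3 (0.62 log units; beyond the scatter).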

Compound 3, half-maximal inhibitory concentration: 105 nM
Estimate against measurement, compound 3: 1.1-fold (0.06 log units) above; measured number inside the range.
By their numbers in this assay, from the lowest: compounds 1 and 3 (each within the scatter of the next); then compound 2.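

Replacing dimethylamino with (1-acetylpyrrolidin-3-yl)amino on a carbonyl carbon gave a 4.8-fold lower number from compound 2 to compound 3 (0.68 log units; beyond the scatter) in this assay, so a second pair now links the hydrogen on the amide-type nitrogen with the lower number, this time with a much larger group attached. The size of the group on that nitrogen made no readable difference between the two secondary amides, since 1-acetylpyrrolidin-3-yl in place of methyl gave a 1.3-fold higher number from compound 1 to compound 3 (0.10 log units; within the scatter) and the ring and acetyl group brought no measurable gain or loss. No measurement available here explains either step.

On these data alone, it remains open whether the acetyl group contributes to the value of compound 3, or whether a free amine on the pyrrolidine would serve equally well. A longer alkyl chain or a carboxylic acid on the amide-type nitrogen is also untested among the compounds shown.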